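This account rests on a few compounds, and the source may have more. Where it says the series, first, only, none or still open, it means among the compounds named here.

In a functional assay on HCT-15 cells (Homo sapiens) for antiproliferative activity, read by MTT assay, with a stated time of 72 h (on this read-out lower numbers stand for stronger inhibition and higher numbers for weaker inhibition), compound 1 (`COc1cc(-c2nccn2Cc2ccccc2)cc(OC)c1OC`) gives > 100000 nM, which is a limit and not a number. Compound 2 (`COc1cc(-c2nccn2-c2ccc3cc[nH]c3c2)cc(OC)c1OC`), which has no benzyl, gives 4000 nM in this assay. Compound 3 (`COc1ccc(-n2ccnc2-c2cc(OC)c(OC)c(OC)c2)cc1`) has 4-methoxyphenyl in place of benzyl on an aromatic nitrogen of a five-membered aromatic ring with 2 nitrogen: 4-methoxyphenyl in place of benzyl on an aromatic nitrogen. For the measured compounds named here, with compound 2 at 4000 nM as the only guide, a large move toward stronger inhibition is expected in this assay. The estimated size of this move is an at least 20-fold lower number from compound 1 to compound 3 (1.30 log units; beyond the scatter). For compound 3 the expected value is 5000 nM, within an estimated range of 800 nM to 35000 nM.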

Compound 3, half-maximal inhibitory concentration: 1300 nM
For compound 3 the middle estimate is 3.8-fold (0.59 log units) above the measured one; low and high end bracket the measured number.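

In this assay, 4-methoxyphenyl in place of benzyl on the aromatic nitrogen gives an at least 76-fold lower number from compound 1 to compound 3 (1.88 log units; beyond the scatter). Compound 3 is thus a second compound without benzyl at this place that gives a measured number, so the move away from the limit no longer rests on compound 2 alone. Compound 1 stands at a limit, so the true size of this step stays unknown: the limit of > 100000 nM in this assay, at which 1 of the 3 values shown sits.

As far as these compounds go, whether the methoxy group of compound 3 plays any part remains open. Neither an unsubstituted phenyl nor a phenyl carrying an amine at this place is among the compounds shown.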